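A group exchange from compound 1 to compound 4

The source may report more compounds than this note shows. Statements on the series, on what has been measured and on what is new or still open speak of the compounds shown alone.

Measured so far in a physicochemical assay for lipophilicity, using the shake flask method; a higher number here means a more lipophilic compound, a lower number a more polar compound:
- compound 1 `CC(C)Oc1cc(Oc2ccc(S(C)(=O)=O)cc2)cc(-c2cncc(=O)[nH]2)c1` gives 2.27
- compound 2 `Cc1cc(=O)[nH]c(-c2cc(Oc3ccc(S(C)(=O)=O)cc3)cc(OC(C)C)c2)n1` gives 2.43
- compound 3 `CCS(=O)(=O)c1ccc(Oc2cc(O[C@@H](C)CO)cc(-c3nccc(=O)[nH]3)c2)cc1` gives 1.42

Compound 1 (2.27) lies within the scatter of compound 2 (2.43), while compound 3 (1.42) sits lower than compound 1 by more than the scatter. Compound 4 `CCc1cnc(-c2cc(Oc3ccc(S(C)(=O)=O)cc3)cc(OC(C)C)c2)[nH]c1=O` has not yet been measured. Its difference from compound 1 is a group of 9 heavy atoms (6 carbon, 2 nitrogen, 1 oxygen; one six-membered aromatic ring with 2 hetero atoms) in place of a group of 7 heavy atoms (4 carbon, 2 nitrogen, 1 oxygen; one six-membered aromatic ring with 2 hetero atoms), on an aromatic carbon, on an aromatic carbon of a six-membered aromatic ring of carbon only. Among the compounds with values here, one measured step bears on this change: a number 0.16 log units higher from compound 1 to compound 2 (within the scatter), where a group of 8 heavy atoms takes the place of the same group of 7 heavy atoms. Within the data shown here, compound 3 differs from compound 1 in more than one place and gives no such step. Compound 4 carries a group of 9 heavy atoms, so a small rise in the same direction as that step is expected, though the step itself offers only weak guidance. The expected step is a number 0.33 log units higher from compound 1 to compound 4 (beyond the scatter) in this assay. For compound 4 the estimated value is 2.6, with an expected range from 2.25 to 2.95.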

Compound 4, distribution coefficient: 3.11
Compound 4: middle estimate off by 0.51 log units, on the low side; the measured number lies above the stated range.
By their numbers in this assay, from the lowest: compound 3; then compounds 1 and 2 (each within the scatter of the next); then compound 4.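

At this position, meta to the isopropoxy group, the group of 9 heavy atoms gives a number 0.84 log units higher from compound 1 to compound 4 (beyond the scatter) in this assay, and a number 0.68 log units higher from compound 2 to compound 4 (beyond the scatter) when set against the group of 8 heavy atoms. The earlier exchange, with a number 0.16 log units higher from compound 1 to compound 2 (within the scatter), had not shown that a change at this place could move the number beyond the scatter, and these new steps show that it can, among groups that share the same ring type and the same counts of hydrogen-bond donors and acceptors. No measurement at hand accounts for the size of these steps. The compounds shown leave open whether a longer chain on this ring would carry the number further, and where an amine or a carboxylic acid there would place it. They also leave open whether the exchange gives a similar step when the isopropoxy group is replaced.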